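A few compounds are considered here, and "the series" means these few. Any claim that something is new, unique, unknown or untested is made for them only; others in the source may bear on it.

Compound 1 `O=S(=O)(NCCCCNCc1ccc(Br)cc1)c1cc(C(F)(F)F)cc(C(F)(F)F)c1`: 2200 nM in a functional assay on BE(2)-C cells (Homo sapiens) for inhibition, read by MTT assay, with a stated time of 72 h; on this read-out higher numbers stand for weaker inhibition of growth and lower numbers for stronger inhibition of growth
Compound 2 `O=S(=O)(NCCCNCC1COc2ccccc2O1)c1cc(C(F)(F)F)cc(C(F)(F)F)c1`: 2800 nM in this assay
Compound 3 `O=S(=O)(NCCCNCc1cccc(Cl)c1)c1cc(C(F)(F)F)cc(C(F)(F)F)c1`: 6900 nM in this assay

All three compounds share the same core, a sulfonamide carrying a bis(trifluoromethyl)phenyl group, and differ only in the group hung from the amine nitrogen at the far end of the chain. Of the three, compound 3 gives the highest number in this assay, which on this read-out means the weakest inhibition of growth: the step of a 3.1-fold higher number from compound 1 to compound 3 (0.50 log units; beyond the scatter) and the step of a 2.5-fold higher number from compound 2 to compound 3 (0.39 log units; beyond the scatter) both lie beyond the usual scatter.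

Compound 4 `O=S(=O)(NCCCNCc1ccc(Cl)cc1)c1cc(C(F)(F)F)cc(C(F)(F)F)c1` is built from the same atoms as compound 3, joined differently: 4-chlorophenyl in place of 3-chlorophenyl on a saturated chain carbon bound to an amine nitrogen. Among the measured compounds shown here, no measured step isolates this change. The closest guide is the step from compound 1 to compound 3, in which a benzyl group bearing a halogen at the 4-position was replaced by one bearing a halogen at the 3-position, along with a change in chain length; that step raised the number by a 3.1-fold higher number from compound 1 to compound 3 (0.50 log units; beyond the scatter). Moving the chlorine back to the 4-position is therefore expected to lower the number by a modest amount, a 2.0-fold lower number from compound 3 to compound 4 (0.29 log units; within the scatter), though the chain-length difference leaves this uncertain. Compound 4 is estimated at 3500 nM, within a range of 1500 nM to 8000 nM.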

Compound 4, concentration for 50% growth inhibition: 2900 nM
Compound 4: middle estimate off by 1.2-fold (0.08 log units), on the high side; measured number inside the range.
By their numbers in this assay, from the lowest: compounds 1, 2 and 4 (each within the scatter of the next); then compound 3.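

Among the compounds shown here, compound 3 and compound 4 have the same atoms and differ only in 3-chlorophenyl versus 4-chlorophenyl on a saturated chain carbon bound to an amine nitrogen, so this is the first step here that isolates where the chlorine sits on the ring: in this assay there is a 2.4-fold lower number from compound 3 to compound 4 (0.38 log units; beyond the scatter), a modest change but one that lies beyond the scatter. With 4-chlorophenyl in place, the gaps to the other two compounds fall within the scatter, with a 1.0-fold higher number from compound 2 to compound 4 (0.02 log units; within the scatter) against the compound whose group is a 2,3-dihydro-1,4-benzodioxin-2-yl and a 1.3-fold higher number from compound 1 to compound 4 (0.12 log units; within the scatter) against the compound that differs in both its chain and its halogen, so at this place the 3-chlorophenyl group alone stands apart. Nothing available explains why moving the chlorine changes the number.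

The compounds shown leave open whether a 3-bromophenyl group would stand apart from the 4-bromophenyl group on the chain of compound 1 as the two chlorophenyl groups do here, and what a change of chain length does on its own. They also leave open how a 4-fluorophenyl group, a 4-methoxyphenyl group or a pyridine ring would behave at this place.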